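The compounds below may be only part of what the source reports. "The series", "measured", "known", "first", "only" and "open" are said of these compounds alone.

Three close analogues share one core and differ only in the halogenated phenyl group. In a functional assay on the whole organism (Abdomen, strain albino) for inhibition, with Mus musculus as the target, in the writhing test, with stated times of 1 h and 8 min, at a dose of 10 mg/kg by the oral route (a higher number here means more inhibition at the dose given (going by the name of the read-out), a lower number less inhibition), compound 1 `CC1=CC[C@@H]2[C@@H](O[C@H](c3ccc(Cl)cc3)OC2(C)C)[C@@H]1O` gives 88%. Compound 2 `CC1=CC[C@@H]2[C@@H](O[C@H](c3ccc(Br)cc3)OC2(C)C)[C@@H]1O` gives 33%, and compound 3 `CC1=CC[C@@H]2[C@@H](O[C@H](c3cccc(Cl)c3)OC2(C)C)[C@@H]1O` gives 27%, the lowest of the three, though its gap to compound 2 lies within the scatter. The move from 4-chlorophenyl to 3-chlorophenyl gave a number 61 percentage points lower from compound 1 to compound 3 (beyond the scatter), a large fall. Compound 4 `CC1=CC[C@@H]2[C@@H](O[C@H](c3ccc(Cl)c(Cl)c3)OC2(C)C)[C@@H]1O` differs from compound 3 by chloro in place of hydrogen on an aromatic carbon, para to a large group and ortho to the chloro already present. This restores a chloro at the place compound 1 carries one, so a rise is expected, but compound 2 with 4-bromophenyl gives only 33%, so the gain is uncertain. Compound 4 is therefore expected at 55%, between 25% and 85%, meaning a number 28 percentage points higher from compound 3 to compound 4 (beyond the scatter).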

Compound 4, a percentage reported as inhibition, in the whole organism at one dose (the size of the read-out at that dose, not a potency): 14%
Beside the measured number, compound 4's estimate is 41 percentage points above it, outside the stated range (below it).
By their numbers in this assay, from the lowest: compound 4; then compounds 3 and 2 (each within the scatter of the next); then compound 1.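

Adding a chloro did not restore the effect: in this assay, this change gave a number 13 percentage points lower from compound 3 to compound 4 (beyond the scatter). Compound 4 holds the chloro of compound 1 and the chloro of compound 3 together, yet a number 74 percentage points lower from compound 1 to compound 4 (beyond the scatter), so the high number of compound 1 does not survive a second chloro on the aromatic ring and the two chloro groups do not add up. Nothing available explains this fall. Open, going by these compounds, is whether a methoxy group or an amine in place of the added chloro would keep or lose the effect.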